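A few compounds are considered here, and "the series" means these few. Any claim that something is new, unique, unknown or untested is made for them only; others in the source may bear on it.

Compound 1 `Cn1c(-c2ccc(NC(=O)CSc3nc4ccccc4o3)cc2)nc(-c2ccccc2)c1-c1ccccc1` was examined in a functional assay on MCF7 cells (Homo sapiens) for cytotoxicity, read by MTT assay, with a stated time of 24 h, tested at 16 ug/mL (on this read-out higher numbers stand for a stronger effect at the one concentration tested and lower numbers for a weaker effect), where compound 1 gives 56%. Compound 2 `Cc1ccc2oc(SCC(=O)Nc3ccc(-c4nc(-c5ccccc5)c(-c5ccccc5)n4C)cc3)nc2c1` differs from it by methyl in place of hydrogen on an aromatic carbon; in this assay compound 2 gives 40.3%, which is a number 15.7 percentage points lower from compound 1 to compound 2 (beyond the scatter). Compound 3 `Cn1c(-c2ccc(NC(=O)CN3CCN(Cc4ccccc4)CC3)cc2)nc(-c2ccccc2)c1-c1ccccc1` carries a different core, and the difference between the two cores is not broken down here; in this assay compound 3 gives 28.3%, the lowest of the three numbers and beyond the scatter from both of the others.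

Compound 4 `Cc1ccc(CN2CCN(CC(=O)Nc3ccc(-c4nc(-c5ccccc5)c(-c5ccccc5)n4C)cc3)CC2)cc1` has not been measured. It differs from compound 3 by methyl in place of hydrogen on an aromatic carbon. Among the measured compounds shown here, this is the same kind of change as the one from compound 1 to compound 2, but the surroundings of the place are not the same: in compound 2 the methyl sits on a ring that is part of a fused or bridged system of two rings, meta to a fused ring and para to a fused ring, whereas in compound 4 it sits on a six-membered aromatic ring of carbon only, para to a large group. For the measured compounds named here, the one earlier instance of the change is a number 15.7 percentage points lower from compound 1 to compound 2 (beyond the scatter), and on that single step, applied to a starting number that is already low, the step from compound 3 to compound 4 in this assay is expected to be a number 8.3 percentage points lower from compound 3 to compound 4 (within the scatter). Compound 4 is therefore estimated to give 20% in this assay, with a range from 6% to 34%.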

Compound 4, a percentage reported as activity, at one concentration (the size of the read-out at that concentration, not a potency): 26%
For compound 4 the middle estimate is 6 percentage points below the measured one; low and high end bracket the measured number.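

Going from benzyl to 4-methylbenzyl gives, in this assay, a number 2.3 percentage points lower from compound 3 to compound 4 (within the scatter), so on the core of compound 3 this methyl leaves no step that stands out from repeat measurements. Set beside the earlier instance of the same change, the two steps cannot be told apart, even though only the first lies beyond the scatter: the same change on two cores in this assay, a number 15.7 percentage points lower (beyond the scatter) from compound 1 to compound 2 and a number 2.3 percentage points lower (within the scatter) from compound 3 to compound 4, 13.4 percentage points apart, within the scatter of two such steps. This shows that the series gives no firm sign of the change acting differently on the two cores, but it does not show that the step carries over unchanged, since there are only two instances, the methyl stands in different surroundings in each, and a real difference between them of moderate size would remain hidden in the scatter.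

The compounds shown leave open what other groups would do in place of this methyl on the benzyl ring, such as a longer chain like ethyl, a methoxy group, chlorine, an amine or a carboxylic acid. They also leave open whether any of these compounds would give a stronger or weaker effect than another at a different concentration, as each number is a read-out at one concentration only.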